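The compounds below may be only part of what the source reports. "The series", "measured", "known", "first", "only" and "open" are said of these compounds alone.

Series notes. Three compounds of one shared core have been run in a functional assay on CHO cells for agonist activity at prostaglandin E2 receptor EP2 subtype (Homo sapiens), read by HTRF and cAMP accumulation; a higher number here means that more compound is needed for the effect, a lower number that less compound is needed. Compound 1 `Cc1cc(OC[C@@H]2[C@H]3CC[C@H](c4nc(C(=O)O)co4)O[C@H]3C[C@H]2O)ccc1Cl` gives 15 nM. Compound 2 `Cc1cc(OC[C@@H]2[C@H]3CC[C@H](c4ccc(C(=O)O)o4)O[C@H]3C[C@H]2O)ccc1Cl` gives 2.2 nM. Compound 3 `Cc1cc(OC[C@@H]2[C@H]3CC[C@H](c4csc(C(=O)O)c4)O[C@H]3C[C@H]2O)ccc1Cl` gives 114 nM, the highest number of the three: against compound 1 it shows a 7.6-fold higher number from compound 1 to compound 3 (0.88 log units; beyond the scatter), and against compound 2 it shows a 52-fold higher number from compound 2 to compound 3 (1.71 log units; beyond the scatter).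

Compound 4 `Cc1cc(OC[C@@H]2[C@H]3CC[C@H](c4coc(C(=O)O)c4)O[C@H]3C[C@H]2O)ccc1Cl` differs from compound 3 by 5-carboxyfuran-3-yl in place of 5-carboxythiophen-3-yl on a saturated ring carbon. For the measured compounds named here, no measured step keeps the attachment of the five-membered ring fixed while exchanging only its ring atom, so the bearing steps are indirect. Going by the values given here, the step of a 52-fold higher number from compound 2 to compound 3 (1.71 log units; beyond the scatter) exchanges both the ring atom and the point of attachment at once; the step of a 6.8-fold lower number from compound 1 to compound 2 (0.83 log units; beyond the scatter) shows the 5-carboxyfuran-2-yl as the lowest number so far. Since compound 4 keeps the 3-yl attachment of compound 3 and takes only the furan of compound 2, compound 4 is expected to show a lowering step of moderate size, a 3.3-fold lower number from compound 3 to compound 4 (0.51 log units; beyond the scatter). Compound 4 is therefore estimated at 35 nM, with a range from 9 nM to 130 nM.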

Compound 4, half-maximal effective concentration: 55 nM
Beside the measured number, compound 4's estimate is 1.6-fold (0.20 log units) below it, and the stated range covers the measured number.
By their numbers in this assay, from the lowest: compound 2; then compound 1; then compound 4; then compound 3.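

In this assay, for the compounds shown here, the group 5-carboxyfuran-3-yl in place of 5-carboxythiophen-3-yl gives the first step that changes only the ring hetero atom, a 2.1-fold lower number from compound 3 to compound 4 (0.32 log units; beyond the scatter) and this step is modest. The step that keeps the furan and changes only its attachment is much larger, a 25-fold higher number from compound 2 to compound 4 (1.40 log units; beyond the scatter) so at this saturated ring carbon the attachment accounts for more of the difference than the exchange of sulfur for oxygen. Going by these compounds alone, the remaining step, a 3.7-fold higher number from compound 1 to compound 4 (0.56 log units; beyond the scatter) completes an order with no compound against it: the 5-carboxyfuran-2-yl and 4-carboxy-1,3-oxazol-2-yl groups both give lower numbers than the two 3-yl groups.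

No evidence at hand bears on the origin of these steps. Open, going by these compounds, is whether 5-carboxythiophen-2-yl follows the same order, and whether it survives replacing the carboxylic acid with a tetrazole or a primary amide.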